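The source may report more compounds than this note shows. Statements on the series, on what has been measured and on what is new or still open speak of the compounds shown alone.

Measured so far:
compound 1 `Nc1scc(CN2CCN(c3ccc([N+](=O)[O-])cc3)CC2)c1C(=O)c1ccc(Cl)cc1` — 2%
compound 2 `Nc1scc(CN2CCN(c3cccc(Cl)c3)CC2)c1C(=O)c1ccc(Cl)cc1` — 1%

In an assay on CHO cells for displacement of a labelled ligand from adenosine receptor A3 (Homo sapiens), read by scintillation counting, with a stated time of 120 min, tested at 10 uM (on this read-out higher numbers stand for more inhibition at the one concentration tested (going by the name of the read-out) and lower numbers for less inhibition), compound 1 gives 2%, the larger of the two numbers shown, but compound 2 gives 1% and the step of a number 1 percentage points lower from compound 1 to compound 2 (within the scatter) lies within the scatter, so the two cannot be ranked against each other. Both sit near the bottom of the percentage scale.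

Compound 3 `Nc1scc(CN2CCN(c3cc(Cl)ccc3Cl)CC2)c1C(=O)c1ccc(Cl)cc1` differs from compound 1 by 2,5-dichlorophenyl in place of 4-nitrophenyl on an amine nitrogen in a ring. Within the data shown here, the one measured step at the same place is the step from compound 1 to compound 2, a number 1 percentage points lower from compound 1 to compound 2 (within the scatter), where 3-chlorophenyl in place of 4-nitrophenyl on an amine nitrogen in a ring produced nothing beyond the scatter. Among the measured compounds shown here, that step is the only guide, and it points to no movement beyond the scatter in this assay; the expected step is no change at the digits printed from compound 1 to compound 3 (within the scatter), effectively flat. Compound 3 is therefore estimated at 2%, with a range from 0% to 12%.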

Compound 3, a percentage reported as inhibition, at one concentration (the size of the read-out at that concentration, not a potency): 1%
For compound 3 the middle estimate is 1 percentage points above the measured one; low and high end bracket the measured number.
By their numbers in this assay, from the lowest: compounds 2, 3 and 1 (each within the scatter of the next).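

In this assay the step with 2,5-dichlorophenyl in place of 4-nitrophenyl on the amine nitrogen in a ring is a number 1 percentage points lower from compound 1 to compound 3 (within the scatter), so a second substituted phenyl group at this position also gives nothing beyond the scatter. Chloro in place of hydrogen on an aromatic carbon gives no change at the digits printed from compound 2 to compound 3 (within the scatter), so a further chloro on the phenyl ring adds no readable difference either. No supporting data bear on this flat result.

Still open, on these data alone, is whether a pyridine ring or a longer alkyl chain in place of the phenyl ring on this nitrogen would move the number beyond the scatter. Equally open, as far as these compounds go, is whether a change elsewhere on the shared core, such as an acetyl group on its free amine, would lift the read-out at all.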